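A few compounds are considered here, and "the series" means these few. Any claim that something is new, unique, unknown or untested is made for them only; others in the source may bear on it.

Measured so far in an ADME assay on MT4 cells (Homo sapiens) for cytotoxicity; on this read-out lower numbers stand for higher toxicity in this test and higher numbers for lower toxicity in this test:
- Compound 1 `O=C(CSc1snnc1-c1ccccc1)Nc1ccccc1F`: in this assay compound 1 gives > 361000 nM, a limit of the assay rather than a number.
- Compound 2 `CCOC(=O)c1ccc(NC(=O)CSc2snnc2-c2ccccc2)c(Br)c1`: compound 2 gives >= 232000 nM, again a limit.
- Compound 3 `COc1ccc(-c2nnsc2SCC(=O)Nc2ccccc2Br)cc1`: compound 3 gives > 286000 nM, also a limit.

Compound 3 thus stands at a limit, the one given as the limit of > 286000 nM in this assay, at which 1 of the 3 values shown sits. Going by the values given here, the two other values are limits as well, one at the limit of > 361000 nM in this assay, at which 1 of the 3 values shown sits, and one at the limit of >= 232000 nM in this assay, at which 1 of the 3 values shown sits; no compound in the set has a measured number, so no measured step exists.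

Compound 4 `O=C(CSc1snnc1-c1ccccc1)Nc1ccccc1Br` differs from compound 3 by hydrogen in place of methoxy on an aromatic carbon. With every shown value at a limit, the expected step from compound 3 to compound 4 in this assay is a step that the limit leaves unreadable from compound 3 to compound 4, none beyond the scatter, and a further limit is the likely report. Compound 4 is estimated at 300000 nM, range 100000 nM to 700000 nM.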

Compound 4, half-maximal cytotoxic concentration: > 307000 nM
Compound 4: no number, only a limit; the forecaster's own chance of this, stated with the estimate: 85%; middle value at least 1.0-fold (0.01 log units) from the limit.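

Compound 4 also gives only a limit, so its steps from compound 1, compound 2 and compound 3 cannot be read. The compounds shown leave open at what concentration any of the four becomes toxic in this assay.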